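The source may hold more compounds than are shown below. What is called first, only, known or untested is meant among the compounds shown, and "the series" means these compounds.

Measured so far:
- compound 1 `COc1ccc2nc(N(Cc3cc(-c4ccccc4F)no3)c3nc4ccc(F)cc4s3)sc2c1` — 51800 nM
- compound 2 `COc1ccc(-c2cc(CN(c3ncccn3)c3nc4ccccc4s3)on2)cc1` — 30500 nM
- compound 3 `COc1cc(-c2cc(CN(c3ncccn3)c3nc4ccccc4s3)on2)cc(OC)c1OC` — 28400 nM

All three compounds were read in a functional assay on A549 cells (Homo sapiens) for antiproliferative activity, read by MTT assay (a lower number here means a stronger inhibitor, a higher number a weaker inhibitor), and all three sit in the weak range. Compound 2 stands second highest of the three numbers: its nearest neighbour is compound 3, whose value lies within the scatter of that of compound 2, and its furthest is compound 1, which also lies within the scatter. Within the data shown here, no single-point step between measured compounds can be drawn; the three values together show a narrow band with no ordering that the scatter would support.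

The next compound, compound 4 `Fc1ccccc1-c1cc(CN(c2ncccn2)c2nc3ccccc3s2)on1`, follows from compound 2 by one change: 2-fluorophenyl in place of 4-methoxyphenyl on an aromatic carbon. The group that enters is the same 2-fluorophenyl that compound 1 carries, and compound 1 gives a value in the same weak band as compound 2, so nothing in the shown numbers points to a move out of that band. The step of a 1.3-fold higher number from compound 2 to compound 4 (0.12 log units; within the scatter) is therefore expected to stay within the scatter, with no clear direction. Compound 4 is estimated at 40000 nM in this assay, with a likely range from 15000 nM to 100000 nM.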

Compound 4, half-maximal inhibitory concentration: 25400 nM
The estimate for compound 4 lay 1.6-fold (0.20 log units) above the measured number; measured number inside the range.
By their numbers in this assay, from the lowest: compounds 4, 3, 2 and 1 (each within the scatter of the next, the first and the last beyond it).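

In this assay, among these compounds, replacing 4-methoxyphenyl with 2-fluorophenyl on the aromatic carbon next to the ring nitrogen of the five-membered ring gives a 1.2-fold lower number from compound 2 to compound 4 (0.08 log units; within the scatter), the first step that can be read at this position. The position therefore accommodates both aryl groups without a difference beyond the scatter, even though the hydrogen-bond acceptor counted on 4-methoxyphenyl is absent from 2-fluorophenyl and the fluorine-bearing ring sits on the same shared core. No available measurement bears on this result, so the step stands without an explanation.

The compounds shown carry only substituted phenyl groups at this position, leaving open how a carboxylic acid, an amine or a longer alkyl chain there would read in this assay. Also open, from the compounds shown here alone, is whether any change at this position can move a compound out of the weak band, and whether the same exchange of 2-fluorophenyl for 4-methoxyphenyl would read the same way on the core of compound 1.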